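This account rests on a few compounds, and the source may have more. Where it says the series, first, only, none or still open, it means among the compounds named here.

Measured so far:
- compound 1 `CCCCC1([C@H](O)/C=C/C2CCC(=O)[C@@H]2CCCCCC(=O)O)CCC1`: 0.032 mg/kg
- compound 2 `CCCCC1([C@H](O)/C=C/C2CCC(=O)[C@@H]2C/C=C\CCCC(=O)OCC)CCC1`: 0.221 mg/kg

In a functional assay on the whole organism (strain Hartley) for inhibition, with Cavia porcellus as the target, with stated times of 15 min and 2 min (on this read-out higher numbers stand for an effect only at larger amounts of compound and lower numbers for an effect already at smaller amounts), compound 1 holds the lower of the two numbers at 0.032 mg/kg, and compound 2 gives 0.221 mg/kg, with the gap between the two lying beyond the scatter.

The next compound to be read is compound 3 `CCCCC1([C@H](O)/C=C/C2CCC(=O)[C@@H]2CCCCSCC(=O)O)CCC1`. Relative to compound 1 it has (carboxymethyl)sulfanyl in place of carboxymethyl on a saturated chain carbon, four bonds along the chain from a saturated ring carbon. Among the compounds with values here, no measured pair isolates this change, so the expectation rests on compound 1 alone and stays loose. A modest move toward a higher number is expected, possibly none beyond the scatter. The expected step is a 1.6-fold higher number from compound 1 to compound 3 (0.19 log units; within the scatter). For compound 3 the estimated value is 0.05 mg/kg, with an expected range of 0.012 mg/kg to 0.2 mg/kg.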

Compound 3, dose for half-maximal effect: 0.0912 mg/kg
Compound 3: middle estimate off by 1.8-fold (0.26 log units), on the low side; measured number inside the range.
By their numbers in this assay, from the lowest: compound 1; then compound 3; then compound 2.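

In this assay, putting (carboxymethyl)sulfanyl in place of carboxymethyl on a saturated chain carbon, four bonds along the chain from a saturated ring carbon, gives a 2.9-fold higher number from compound 1 to compound 3 (0.45 log units; beyond the scatter). Within the data shown here, this is the first pair that differs in one place, and it shows that this position is not indifferent to the change, although the step is modest. Nothing available on the compounds accounts for the step.

The compounds shown do not separate the contribution of the sulfur from that of the added chain length; an ether oxygen in place of the sulfur, or an all-carbon chain of the same length, would do so. Also open, as far as these compounds go, is how a primary amide in place of the carboxylic acid would read at the end of this chain.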